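The source may report more compounds than this note shows. Statements on the series, on what has been measured and on what is new or still open speak of the compounds shown alone.

Of the compounds shown here, three built on one shared core have been measured in a functional assay for agonist activity at Bile acid receptor (Homo sapiens), read by a luciferase reporter; on this read-out higher numbers stand for larger maximal responses and lower numbers for smaller maximal responses. Compound 1 `O=C(O)c1cccc(NC(=O)C(C2CCCCC2)n2c(-c3ccc(Cl)cc3)nc3cc(F)c(F)cc32)c1` gives 14%, compound 2 `O=C(O)Cc1ccc(NC(=O)C(C2CCCCC2)n2c(-c3ccc(Cl)cc3)nc3cc(F)c(F)cc32)cc1` gives 14%, and compound 3 `O=C(O)CCc1ccc(NC(=O)C(C2CCCCC2)n2c(-c3ccc(Cl)cc3)nc3cc(F)c(F)cc32)cc1` gives 18%. All three carry an acid-bearing aromatic group on an amide-type nitrogen and differ only in how that acid is attached. Compound 3 holds the top number of the three, but only on paper: a number 4 percentage points higher from compound 1 to compound 3 (within the scatter), a number 4 percentage points higher from compound 2 to compound 3 (within the scatter), and likewise no change at the digits printed from compound 1 to compound 2 (within the scatter). No ranking can be read from these numbers.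

Compound 4 `O=C(O)c1ccc(NC(=O)C(C2CCCCC2)n2c(-c3ccc(Cl)cc3)nc3cc(F)c(F)cc32)nc1` has not yet been measured in this assay. It differs from compound 3 in one place: 5-carboxypyridin-2-yl in place of 4-(2-carboxyethyl)phenyl on an amide-type nitrogen. The acid thus leaves the 2-carboxyethyl chain and sits directly on a six-membered aromatic ring with 1 hetero atom.

The three measured steps bear on this change: each of them also rearranged the acid-bearing group, and none of them moved the response beyond the scatter. Nothing in these data singles out the ring nitrogen for a different outcome. The expected step is therefore a number 3 percentage points lower from compound 3 to compound 4 (within the scatter), that is, none beyond the scatter. Compound 4 is estimated at 15%, within a range from 4% to 28%.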

Compound 4, largest response reached (reported as efficacy), in percent of the reference or control that the assay uses: 20%
Beside the measured number, compound 4's estimate is 5 percentage points below it, within the range that was stated.
By their numbers in this assay, from the lowest: compounds 1, 2, 3 and 4 (each within the scatter of the next).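

In this assay, replacing the 4-(2-carboxyethyl)phenyl group with 5-carboxypyridin-2-yl on the amide-type nitrogen gives a number 2 percentage points higher from compound 3 to compound 4 (within the scatter) and the other two swaps on that nitrogen give a number 6 percentage points higher from compound 2 to compound 4 (within the scatter) and a number 6 percentage points higher from compound 1 to compound 4 (within the scatter). Within the data shown here, this is the first group here with a hetero atom in its six-membered aromatic ring, and the response at this position stays within the scatter of all three groups whose rings hold carbon only, even though the 2-carboxyethyl chain is gone and the acid sits directly on the ring. No accompanying measurement bears on why the response holds steady, so this result remains unexplained.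

This step changes the ring atom and the acid's attachment together, and a 4-carboxyphenyl group on the same nitrogen would separate those two changes. Going by these compounds, whether an amine or a primary amide in place of the carboxylic acid, or a longer chain such as 3-carboxypropyl, would carry the response beyond the scatter remains open.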